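A carbamoylpiperidine replaces the tert-butylamine

A few compounds are considered here, and "the series" means these few. Any claim that something is new, unique, unknown or untested is made for them only; others in the source may bear on it.

Three measured compounds share one core and differ only in the group carried on the amine nitrogen of the side chain. Compound 1 `CNCC(=O)N1N=C(c2cc3ccccc3oc2=O)CC1c1ccccc1` gives 24000 nM in a functional assay on HepG2 cells (Homo sapiens) for cytotoxicity, read by MTT assay, with a stated time of 48 h; a higher number here means a weaker inhibitor, a lower number a stronger inhibitor. Compound 2 `CC(C)CNCC(=O)N1N=C(c2cc3ccccc3oc2=O)CC1c1ccccc1` gives 9970 nM in this assay, and compound 3 `CC(C)(C)NCC(=O)N1N=C(c2cc3ccccc3oc2=O)CC1c1ccccc1` gives 31400 nM in this assay. Compound 3 thus stands at the highest of the three numbers, although its gap to compound 1 is within the scatter; only its gap to compound 2 is beyond it.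

The steps between them are modest. There is a 2.4-fold lower number from compound 1 to compound 2 (0.38 log units; beyond the scatter). There is a 3.1-fold higher number from compound 2 to compound 3 (0.50 log units; beyond the scatter), and there is a 1.3-fold higher number from compound 1 to compound 3 (0.12 log units; within the scatter).

Compound 4 `NC(=O)C1CCN(CC(=O)N2N=C(c3cc4ccccc4oc3=O)CC2c2ccccc2)CC1` changes the same position: 4-carbamoylpiperidin-1-yl in place of (tert-butyl)amino on a saturated chain carbon bound to a carbonyl carbon. Within the data shown here, no measured step brings in a ring or a carboxamide, so the three steps bear on this change only in that they show how much the amine substituent has moved the number so far, and that range is narrow in both directions.

Compound 4 is therefore expected to give about 20000 nM in this assay, with a range from 6000 nM to 60000 nM. The expected step from this estimate is a 1.6-fold lower number from compound 3 to compound 4 (0.20 log units; within the scatter), which is judged likely to stay within the scatter.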

Compound 4, half-maximal inhibitory concentration: 19300 nM
Compound 4: the middle estimate sits 1.0-fold (0.02 log units) above what was measured; measured number inside the range.
By their numbers in this assay, from the lowest: compounds 2, 4, 1 and 3 (each within the scatter of the next, the first and the last beyond it).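

In this assay, among these compounds, the place on a saturated chain carbon bound to a carbonyl carbon accepts 4-carbamoylpiperidin-1-yl, the first group here with a six-membered non-aromatic ring and a carbonyl of its own, and the number cannot be told apart from that of any of the three open-chain amines (a 1.6-fold lower number from compound 3 to compound 4 (0.21 log units; within the scatter); a 1.9-fold higher number from compound 2 to compound 4 (0.29 log units; within the scatter); a 1.2-fold lower number from compound 1 to compound 4 (0.09 log units; within the scatter)). The added heavy atoms and the ring therefore leave the number inside the span already set by compound 2 and compound 3, and compound 4 sits within the scatter of both even though those two stand beyond the scatter of each other. Nothing available gives a reason for this flat response or says whether the cytotoxic effect has the same origin across these four compounds.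

The compounds shown leave open what the ring and the carboxamide each contribute, as they enter together in compound 4 and a plain piperidine does not stand among them. Also open, from the compounds shown here alone, is how a carboxylic acid in place of the carboxamide, or a morpholine in place of the whole group, would read at this place.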